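A few compounds are considered here, and "the series" means these few. Any claim that something is new, unique, unknown or untested is made for them only; others in the source may bear on it.

Compound 1 `O=C(CCc1ccc(C(F)(F)F)cc1)Nc1ccc2nc(N3CCCC3)ccc2c1` gives 320 nM; 320 nM (2 entries) in a functional assay on HEK293 cells for activation of melanin-concentrating hormone receptor 1 (Rattus norvegicus), read by inositol phosphate accumulation; on this read-out lower numbers stand for an effect already at smaller amounts and higher numbers for an effect only at larger amounts of compound. Going by the values given here, compound 2 `O=C(CCc1ccc(C(F)(F)F)cc1)Nc1ccc2nc(N3CC4CCC3CC4)ccc2c1` gives 190 nM in this assay, the only number that stands for it there. Compound 3 `O=C(CCc1ccc(C(F)(F)F)cc1)Nc1ccc2nc(N3CC4CCC3C4)ccc2c1` differs from compound 2 by a group of 7 heavy atoms (6 carbon, 1 nitrogen; one five-membered non-aromatic ring of carbon only, one five-membered non-aromatic ring with 1 hetero atom) in place of a group of 8 heavy atoms (7 carbon, 1 nitrogen; 2 six-membered non-aromatic rings with 1 hetero atom each), on an aromatic carbon, so the bridged amine on the shared core loses one ring member. Among the compounds with values here, no measured pair shows this step, and the two measured compounds alone give no guide to its size; a step of a 1.2-fold higher number from compound 2 to compound 3 (0.06 log units; within the scatter) is expected, essentially none beyond the scatter. Compound 3 is therefore estimated at 220 nM, within a range from 100 nM to 500 nM.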

Compound 3, half-maximal effective concentration: 150 nM
Beside the measured number, compound 3's estimate is 1.5-fold (0.17 log units) above it, and the stated range covers the measured number.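

Going by these compounds alone, removing one ring member from the bridged amine gives a 1.3-fold lower number from compound 2 to compound 3 (0.10 log units; within the scatter) in this assay, the first measured step at this position. This aromatic carbon therefore carries either bridged amine with no difference that this assay can separate. Nothing measured for these compounds bears on this result.

As far as these compounds go, whether a morpholine or an open-chain diethylamine on this aromatic carbon would read in the same range in this assay remains open. From the compounds shown here alone, it is also open whether the step would stay as small with a chlorine in place of the trifluoromethyl.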